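This account rests on a few compounds, and the source may have more. Where it says the series, first, only, none or still open, it means among the compounds named here.

Compound 1 `CNC(=O)/C=C/c1ccncc1-c1ccc2ccccc2c1` and compound 2 `O=C(/C=C/c1ccncc1-c1ccc2ccccc2c1)NC1CC1` share one core and differ only at the amide-type nitrogen. In a functional assay on KB cells (Homo sapiens) for inhibition, read by sulforhodamine B assay, with a stated time of 72 h (on this read-out higher numbers stand for weaker inhibition of growth and lower numbers for stronger inhibition of growth), compound 1 gives > 10000 nM, which is a limit of the assay rather than a number. In this assay compound 2 gives 6050 nM. Within the data shown here, the step of an at least 1.6-fold lower number from compound 1 to compound 2 (0.21 log units; that floor lies within the scatter) is the only measured step, and its size is known only as a floor because of the limit of > 10000 nM in this assay, at which 1 of the 2 values shown sits. Compound 2 therefore holds the only number shown; the other value is a limit. Compound 3 `CN1CCN(C(=O)/C=C/c2ccncc2-c2ccc3ccccc3c2)CC1` carries the change (4-methylpiperazin-1-yl in place of cyclopropylamino on a carbonyl carbon). This change also sits on the amide side of the core, but reaches further than the measured step: the cyclopropylamino group leaves, and with it the hydrogen-bond donor, while a 4-methylpiperazin-1-yl ring enters on the carbonyl carbon. Among the measured compounds shown here, no measured step covers such a change, and the one step that touches the same region reads only as a floor within the scatter. The expectation for compound 3 in this assay is therefore no step beyond the scatter, with a real chance that the assay again returns only a limit. For compound 3 the estimate is 7000 nM, between 2500 nM and 20000 nM, which means an expected step of a 1.2-fold higher number from compound 2 to compound 3 (0.06 log units; within the scatter).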

Compound 3, concentration for 50% growth inhibition: > 10000 nM
Compound 3 ended at the assay's limit (the forecaster's own chance of this, stated with the estimate: 30%); middle value at least 1.4-fold (0.15 log units) away from the limit.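

In this assay, putting 4-methylpiperazin-1-yl in place of cyclopropylamino on the carbonyl carbon removes the hydrogen-bond donor of the amide and gives an at least 1.6-fold higher number from compound 2 to compound 3 (0.21 log units; that floor lies within the scatter). Compound 3 gives > 10000 nM, which is a limit of the assay and not a number, so this change, like the change from methylamino to cyclopropylamino, yields no step shown to lie beyond the scatter. The step from compound 1 to compound 3 cannot be read, and compound 2 remains the only compound with a number, because most of the series sits at the top of the measurable range: the limit of > 10000 nM in this assay, at which 2 of the 3 values shown sit.

On these data alone, it remains open whether any group on this carbonyl carbon can move the growth inhibition beyond the scatter of compound 2, for example a morpholine ring, a longer alkyl chain on the amide nitrogen, or a carboxylic acid in place of the amide. As far as these compounds go, it is also open whether the loss of the amide hydrogen matters apart from the change of ring, a question that an N-methyl-N-cyclopropylamino group on the same carbon would separate.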